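The source may hold more compounds than are shown below. What is called first, only, known or untested is meant among the compounds shown, and "the series" means these compounds.

In a functional assay on PANC-1 cells (Homo sapiens) for inhibition, read by MTT assay, with a stated time of 24 h, tested at 10 uM (a lower number here means less inhibition, a higher number more inhibition at the concentration tested (going by the name of the read-out)), compound 2 `CC(C)=CCC1Cc2c(OCCCOc3ccc(Cl)cc3)cc(=O)n(CCCO)c2CC1(C)C` gives 0%, the lowest of the two numbers available. Within the data shown here, compound 1 `CC(C)=CCC1Cc2c(OCc3ccccc3)cc(=O)n(CCCO)c2CC1(C)C` gives 11.1%, and the single measured step, a number 11.1 percentage points lower from compound 1 to compound 2 (beyond the scatter), led to that low figure. Compound 3 `COc1ccc(NC(=O)Oc2cc(=O)n(CCCO)c3c2CC(CC=C(C)C)C(C)(C)C3)cc1` differs from compound 2 in this way: (4-methoxyphenyl)carbamoyl in place of 3-(4-chlorophenoxy)propyl on an oxygen on an aromatic ring. Among the measured compounds shown here, no measured step involves a (4-methoxyphenyl)carbamoyl group, so that one step offers no direct guide, and both known values point only to weak inhibition for this core. Compound 3 is therefore expected to show little or no change beyond the scatter, a number 8 percentage points higher from compound 2 to compound 3 (within the scatter), with an estimated 8% ranging from 0% to 25%.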

Compound 3, a percentage reported as inhibition, at one concentration (the size of the read-out at that concentration, not a potency): 0%
Estimate against measurement, compound 3: 8 percentage points above, and the stated range covers the measured number.
By their numbers in this assay, from the lowest: compounds 2 and 3 (each within the scatter of the next); then compound 1.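

In this assay, the change on the oxygen on an aromatic ring gives no change at the digits printed from compound 2 to compound 3 (within the scatter), and putting the same (4-methoxyphenyl)carbamoyl group in place of benzyl gives a number 11.1 percentage points lower from compound 1 to compound 3 (beyond the scatter). The group bearing a nitrogen and a hydrogen-bond donor therefore reads alike with the 3-(4-chlorophenoxy)propyl chain, and among these three compounds only compound 1, with benzyl, stands apart from the others. Nothing available explains this result.

As far as these compounds go, whether a plain phenylcarbamoyl group, a methyl ether or an amine-bearing chain at this oxygen would lift the reading remains open. Because compound 2 and compound 3 share the same reading, any difference between them remains unresolved.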